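Removing the propyl group from compound 1

A few compounds are considered here, and "the series" means these few. Any claim that something is new, unique, unknown or untested is made for them only; others in the source may bear on it.

Compound 1 `CCCOCC1=CS(=O)(=O)c2ccccc2C1=O` carries a propyl group on an oxygen attached to a saturated carbon of the shared core. Within the data shown here, in a functional assay on the whole organism for inhibition, with Mus musculus as the target, at a dose of 10 mg/kg (on this read-out lower numbers stand for less inhibition and higher numbers for more inhibition at the one dose given (going by the name of the read-out)), compound 1 gives 99.9%; only one other compound has been measured, and its number lies within the scatter of this one. That other compound is compound 2 `CCC(=O)OCC1=CS(=O)(=O)c2ccccc2C1=O`, in which a propanoyl group stands where the propyl group was; in this assay compound 2 gives 99.5%. Among the measured compounds shown here, the single measured step, a number 0.4 percentage points lower from compound 1 to compound 2 (within the scatter), is within the scatter and shows only that exchanging one group for another on this oxygen left the read-out essentially unchanged.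

Compound 3 `O=C1C(CO)=CS(=O)(=O)c2ccccc21` has not yet been measured. It differs from compound 1 by hydrogen in place of propyl on an oxygen on a saturated carbon. The step from compound 1 to compound 2 is the only one that bears on this change, and it was small; it swapped one group for another, whereas here the propyl is removed altogether, leaving a hydroxymethyl group. With both measured numbers high and level with each other, the expected step is a number 4.9 percentage points lower from compound 1 to compound 3 (within the scatter), not larger than the scatter. Compound 3 is therefore estimated at 95%, within a range from 70% to 100%.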

Compound 3, a percentage reported as inhibition, in the whole organism at one dose (the size of the read-out at that dose, not a potency): 99.3%
Compound 3: middle estimate off by 4.3 percentage points, on the low side; the range from low to high includes it.
By their numbers in this assay, from the lowest: compounds 3, 2 and 1 (each within the scatter of the next).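

In this assay, the step with the propyl group removed altogether is a number 0.6 percentage points lower from compound 1 to compound 3 (within the scatter), and the step with the propanoyl group removed is a number 0.2 percentage points lower from compound 2 to compound 3 (within the scatter). Among these compounds, until now, this oxygen had been seen only with one group exchanged for another; these steps show that the read-out stays level even with nothing but hydrogen there, leaving a plain hydroxymethyl group on the shared core. No measurement available here speaks to what lies behind this level reading.

All three numbers sit close to the top of the scale at a single dose, so this read-out cannot show whether the three compounds would separate at a smaller dose. The compounds shown also leave open whether the read-out would stay level with a longer chain or a benzyl group on this oxygen, or with an amine or a carboxylic acid in place of the hydroxy group.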